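From azetidin-1-yl to (2-methoxyphenyl)amino on the shared core

The source may hold more compounds than are shown below. What is called first, only, known or untested is meant among the compounds shown, and "the series" means these compounds.

Compound 1 `O=C1C=C(N2CCC2)C(=O)c2c1nc1n2[C@H]2OC[C@@H](O)[C@H]2OC1` opens this step. In a functional assay on MCF7 cells (Homo sapiens) for inhibition, read by sulforhodamine B assay (a higher number here means a weaker inhibitor, a lower number a stronger inhibitor), compound 1 gives > 16000 nM, which is a limit of the assay and not a number. Compound 2 `O=C1C(Nc2ccc(Br)cc2)=CC(=O)c2c1nc1n2[C@H]2OC[C@@H](O)[C@H]2OC1`, which also has a six-membered aromatic ring of carbon only in its group on the double-bonded ring carbon, gives 4330 nM in this assay. Compound 3 `COc1ccccc1NC1=CC(=O)c2nc3n(c2C1=O)[C@H]1OC[C@@H](O)[C@H]1OC3` has (2-methoxyphenyl)amino in place of azetidin-1-yl on a double-bonded ring carbon. A move toward stronger inhibition in this assay is expected, on the evidence of compound 2 at 4330 nM. The expected step is an at least 2.6-fold lower number from compound 1 to compound 3 (0.42 log units; beyond the scatter). Compound 3 is estimated at 6000 nM, within an expected range of 1800 nM to 16000 nM.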

Compound 3, half-maximal inhibitory concentration: > 4000 nM
Compound 3: a limit, no number (the forecaster's own chance of this, stated with the estimate: 20%); the middle value is on the limit's open side.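

In this assay compound 1 gives > 16000 nM, a limit of the assay and not a number. Compound 3 gives > 4000 nM, also a limit, so no step can be read between compound 1 and compound 3. From the compounds shown here alone, how far (2-methoxyphenyl)amino in place of azetidin-1-yl shifts inhibition on the shared core, and in which direction, stays open.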